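The compounds below may be only part of what the source reports. "The series", "measured", "known", "first", "only" and "open" are said of these compounds alone.

Of the compounds shown here, two sharing one core have been measured in an ADME assay on A2780 cells (Homo sapiens) for inhibition, read by trypan blue exclusion, with a stated time of 72 h; on this read-out higher numbers stand for weaker inhibition of growth and lower numbers for stronger inhibition of growth. Compound 1 `O=C(/C=C/c1ccccc1)c1cccc([N+](=O)[O-])c1` gives 4300 nM and compound 2 `COc1cccc(C(=O)/C=C/c2ccccc2)c1` gives 8000 nM, so compound 2 stands within the usual scatter of compound 1. Compound 3 `O=C(/C=C/c1ccccc1)c1cccc(C(F)(F)F)c1` carries trifluoromethyl in place of methoxy on an aromatic carbon. Among the compounds with values here, only one measured step bears on this swap. Since methoxy in place of nitro gave a 1.9-fold higher number from compound 1 to compound 2 (0.27 log units; within the scatter), no step beyond the scatter is expected in this assay for this change. The estimated step is a 1.5-fold lower number from compound 2 to compound 3 (0.16 log units; within the scatter). For compound 3 the expected value is 5500 nM, with an estimated range of 2200 nM to 14000 nM.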

Compound 3, concentration for 50% growth inhibition: > 20000 nM
Compound 3: no number, only a limit; the forecaster's own chance of this, stated with the estimate: 3%; middle value at least 3.6-fold (0.56 log units) away from the limit.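

Nitro and methoxy at this position gave numbers within the scatter of each other, so the earlier pair gave no sign that the group placed here matters in this assay. Trifluoromethyl does separate from both, with an at least 2.5-fold higher number from compound 2 to compound 3 (0.39 log units; beyond the scatter) and an at least 4.6-fold higher number from compound 1 to compound 3 (0.66 log units; beyond the scatter). Compound 3 gives a limit and not a number, so both steps are minimum sizes: the limit of > 20000 nM in this assay, at which 1 of the 3 values shown sits.

The compounds shown do not tell what sets trifluoromethyl apart from nitro and methoxy. From the compounds shown here alone, whether an amine or a carboxylic acid at this position would read like compound 1 or like compound 3 also stays open.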